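Volume of distribution in the series: compound 1 to compound 4

The source may hold more compounds than are shown below. What is called first, only, known or untested is meant among the compounds shown, and "the series" means these compounds.

Measured so far:
- compound 1 `CCn1c(-c2cnc(C)nc2)nc2c(N[C@H]3CCN(C(=O)C4CCC4)C3)ncnc21`: 9.2 L/kg
- compound 2 `CCn1c(-c2ccc(C(F)(F)F)nc2)nc2c(O[C@H]3CCN(C(=O)N4CC(OC)C4)C3)ncnc21`: 4.2 L/kg
- compound 3 `CCn1c(-c2cnc(C)nc2)nc2c(O[C@H]3CCN(C(=O)C4CCC4)C3)ncnc21`: 4 L/kg

The three measured compounds were tested in an ADME assay (Rattus norvegicus, strain Wistar Han) for pharmacokinetics; a higher number here means that more of the compound sits outside the plasma, a lower number that more of the compound stays in the plasma. Compound 1 stands highest of the three numbers; its nearest neighbour is compound 2, and the gap to compound 2 as well as the wider gap to compound 3 both lie beyond the scatter of repeated measurements. Among the compounds with values here, no step between measured compounds that differ in one place is available, so the three values speak only for themselves.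

Compound 4 `CCC(=O)N1CC[C@H](Nc2ncnc3c2nc(-c2cnc(C)nc2)n3CC)C1` has not yet been measured in this assay. It differs from compound 1 in one place: ethyl in place of cyclobutyl on a carbonyl carbon. Cyclobutylcarbonyl becomes propanoyl, the carbonyl carbon keeping its amide-type nitrogen in a ring. Nothing in the measured set shows what such a change does to volume of distribution. The expectation is for a small step downward, or none beyond the scatter, estimated as a 1.3-fold lower number from compound 1 to compound 4 (0.12 log units; within the scatter). Compound 4 is estimated at 7 L/kg, with a range from 3.5 L/kg to 14 L/kg, because compound 1 gives 9.2 L/kg and the change is modest.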

Compound 4, volume of distribution: 3.6 L/kg
Beside the measured number, compound 4's estimate is 1.9-fold (0.29 log units) above it; the measured number falls inside the stated range.
By their numbers in this assay, from the lowest: compounds 4, 3 and 2 (each within the scatter of the next); then compound 1.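

Within the data shown here, on a carbonyl carbon whose other neighbour is an amide-type nitrogen in a ring, ethyl in place of cyclobutyl gives a 2.6-fold lower number from compound 1 to compound 4 (0.41 log units; beyond the scatter), the only single-place step available in this assay, so this position does register in the read-out. Cyclobutyl and ethyl both carry no hydrogen-bond donors or acceptors and no net charge, so the step goes with the loss of the four-membered carbon ring and the drop from 4 carbons to 2, and these two differences cannot be told apart here. Nothing at hand accounts for the size of the step or gives a cause for it.

From the compounds shown here alone, whether the ring or the carbon count carries the step stays open, and a cyclopropyl group or a longer chain such as butyl on the same carbonyl carbon would help to separate the two, while a terminal amine on that chain would test a different kind of group there. Also open, going by these compounds, is whether the same change would give a step of this size from compound 3, which stands at 4 L/kg and carries the same cyclobutylcarbonyl group.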